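A few compounds are considered here, and "the series" means these few. Any claim that something is new, unique, unknown or untested is made for them only; others in the source may bear on it.

Compound 1 `N=C(N)Nc1ccc2[nH]c(-c3ccccc3)nc2c1`: > 100 ug/mL (a limit)
Compound 2 `N#Cc1ccc(-c2nc3cc(NC(=N)N)ccc3[nH]2)cc1`: > 100 ug/mL (a limit)

In an ADME assay on L6 cells (Rattus norvegicus) for cytotoxicity, read by fluorescence and resazurin assay, with a stated time of 70 h (a higher number here means a weaker inhibitor, a lower number a stronger inhibitor), compound 2 stands at > 100 ug/mL, which is a limit of the assay and not a number. Its neighbour offers no number either: the limit of > 100 ug/mL in this assay, at which 2 of the 2 values shown sit. Compound 3 `N=C(N)Nc1ccc2[nH]c(-c3ccc(-c4ccccc4)cc3)nc2c1` has phenyl in place of cyano on an aromatic carbon, para to a large group: phenyl in place of cyano on an aromatic carbon. For the measured compounds named here, the only measured step is a step that the two limits leave unreadable from compound 1 to compound 2, which placed cyano where hydrogen stood on an aromatic carbon, so it gives no size to carry over. A modest move toward a lower number in this assay is therefore expected only as a cautious guess, and another reading at the limit remains about as likely. The expected change is an at least 1.4-fold lower number from compound 2 to compound 3 (0.15 log units; that floor lies within the scatter). For compound 3 the estimate is 70 ug/mL, with an expected range from 20 ug/mL to 120 ug/mL.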

Compound 3, half-maximal inhibitory concentration: 46.2 ug/mL
Beside the measured number, compound 3's estimate is 1.5-fold (0.18 log units) above it, and the stated range covers the measured number.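

In this assay, for the compounds shown here, phenyl in place of cyano on an aromatic carbon, para to a large group, gives an at least 2.1-fold lower number from compound 2 to compound 3 (0.33 log units; beyond the scatter), the first readable change at this position, as the step from hydrogen to cyano could not be read. Phenyl in place of hydrogen at the same carbon gives an at least 2.1-fold lower number from compound 1 to compound 3 (0.33 log units; beyond the scatter), so the change holds against both neighbours and lies beyond the scatter. Compound 3 is the only one of the three that gives a number rather than a limit: the limit of > 100 ug/mL in this assay, at which 2 of the 3 values shown sit.

From the compounds shown here alone, both steps are floors, so their true size stays open, as does whether the aromatic ring itself or simply the larger count of heavy atoms goes with the lower number. Going by these compounds, how an amine, a carboxylic acid or a longer chain on this carbon would read also remains open.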